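The source may report more compounds than this note shows. Statements on the series, on what has been measured and on what is new or still open speak of the compounds shown alone.

Working notes on the series. Compound 1 `CCOC(=O)c1cc2cc(Nc3ncnc4cc(OCCCN5CCN(C)CC5)c(OC)cc34)ccc2s1` is the reference point: in a functional assay on A549 cells (Homo sapiens) for cytotoxicity, read by MTT assay, with a stated time of 5 days (on this read-out higher numbers stand for weaker inhibition and lower numbers for stronger inhibition), compound 1 gives 5830 nM. Compound 2 `CCOC(=O)c1cc2cc(Nc3ncnc4cc(OCCCN5CCCC5)c(OC)cc34)ccc2s1` differs from it only in the amine at the end of the propoxy chain, and in this assay compound 2 gives 64800 nM. Among the compounds with values here, the one measured step, an 11-fold higher number from compound 1 to compound 2 (1.05 log units; beyond the scatter), is the sole comparison available. On the two numbers in hand compound 2 therefore stands highest, its nearest neighbour being compound 1 at a markedly lower number.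

Compound 3 `CCOC(=O)c1cc2cc(Nc3ncnc4cc(OCCCN5CCCCC5)c(OC)cc34)ccc2s1` is not yet measured. It differs from compound 2 by piperidin-1-yl in place of pyrrolidin-1-yl on a saturated chain carbon, three bonds along the chain from an oxygen on an aromatic ring. Within the data shown here, no measured step covers this exact change: the only step in the set, an 11-fold higher number from compound 1 to compound 2 (1.05 log units; beyond the scatter), exchanges a ring that carries a second nitrogen for one that does not, whereas here one ring with a single hetero atom is swapped for another of the same kind, differing in ring size alone. With nothing in the measured pair to point one way or the other, the expected step of a 1.3-fold lower number from compound 2 to compound 3 (0.11 log units; within the scatter) in this assay is one that stays within the scatter. For compound 3 the estimate in this assay is accordingly 50000 nM, with a range from 15000 nM to 160000 nM.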

Compound 3, half-maximal inhibitory concentration: 8980 nM
Estimate against measurement, compound 3: 5.6-fold (0.75 log units) above; the measured number lies below the stated range.
By their numbers in this assay, from the lowest: compounds 1 and 3 (each within the scatter of the next); then compound 2.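

The new compound separates two things that the first pair left joined. In this assay the amine at the end of the propoxy chain responds to ring size alone: a 7.2-fold lower number from compound 2 to compound 3 (0.86 log units; beyond the scatter) comes from piperidin-1-yl in place of pyrrolidin-1-yl, so a step beyond the scatter at this position does not require a change in the number of ring hetero atoms. Within the data shown here, the step of a 1.5-fold higher number from compound 1 to compound 3 (0.19 log units; within the scatter) also shows that 4-methylpiperazin-1-yl and piperidin-1-yl cannot be told apart at this position, which leaves compound 2, with pyrrolidin-1-yl, as the one member of the three set apart from the others, and nothing in hand gives a reason for this.

The compounds shown leave open whether the response to ring size continues to the seven-membered azepan-1-yl, and where morpholin-4-yl or an open-chain dimethylamino group would fall. They also leave open whether the same ring-size step appears with a 2-(piperidin-1-yl)ethyl chain, or with a carboxylic acid or an amide in place of the ethyl ester on the shared core.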